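Swapping a fluoropropoxy chain for a single fluorine

This account rests on a few compounds, and the source may have more. Where it says the series, first, only, none or still open, it means among the compounds named here.

Of the compounds shown here, two of a shared core have been measured in an assay on HEK293 cells for displacement of a labelled ligand from Neuronal acetylcholine receptor; alpha3/beta4 (Homo sapiens), read by scintillation counting, with a stated time of 120 min; a higher number here means a weaker inhibitor, a lower number a stronger inhibitor. Compound 1 `Fc1cccc(-c2cn([C@@H]3CN4CCC3CC4)nn2)c1` gives 2.25 nM. Compound 2 `FCCCOc1cccc(-c2cn([C@H]3CN4CCC3CC4)nn2)c1` gives 1630 nM, the higher of the two numbers, and its distance from compound 1 is far beyond the usual scatter, so compound 2 is clearly the weaker binder of the pair.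

Compound 3 `Fc1cccc(-c2cn([C@H]3CN4CCC3CC4)nn2)c1` has not yet been measured. It arises from compound 2 by one change: fluoro in place of 3-fluoropropoxy on an aromatic carbon. The single fluorine that enters is the same group that compound 1 carries on its aromatic ring, although compound 1 and compound 3 are not a pair whose difference has been worked out here.

Going by the values given here, no measured pair shows this exact replacement, so its effect must be guessed. A large move toward stronger binding is expected, because compound 1, which carries a fluoro group on the ring, gives 2.25 nM in this assay. The expected step from compound 2 to compound 3 is a 16-fold lower number from compound 2 to compound 3 (1.21 log units; beyond the scatter). Compound 3 is therefore estimated at 100 nM, within a broad range from 5 nM to 2000 nM.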

Compound 3, inhibition constant: 362 nM
Estimate against measurement, compound 3: 3.6-fold (0.56 log units) below; low and high end bracket the measured number.
By their numbers in this assay, from the lowest: compound 1; then compound 3; then compound 2.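

Compound 2 and compound 3 share the same drawn configuration, so they isolate the aromatic substituent: the result is a 4.5-fold lower number from compound 2 to compound 3 (0.65 log units; beyond the scatter). Removing the 3-fluoropropoxy chain in favour of fluoro therefore strengthens binding, but only modestly, and fluoro on this aromatic carbon does not by itself give a number close to the low value of the other fluoro compound. That gap is far larger, a 160-fold higher number from compound 1 to compound 3 (2.21 log units; beyond the scatter), with the same atoms and bonds on both sides and a stereocentre at a saturated ring carbon drawn S in one and R in the other, so the stereocentre is the only recorded difference behind it, and the record reads: the fact that one of compounds 1 and 3 is drawn with a defined configuration and the other without, at the place where they differ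

The compounds shown leave open whether exchanging the 3-fluoropropoxy chain for fluoro would have a step of similar size on the S form, as no pair here tests that. Also open, going by these compounds, is how a methoxy group, an amine or a longer chain on this aromatic carbon would compare with fluoro and 3-fluoropropoxy.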